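The source may hold more compounds than are shown below. What is called first, only, known or untested is meant among the compounds shown, and "the series" means these compounds.

In an ADME assay on KB cells (Homo sapiens) for cytotoxicity (a lower number here means that less compound is needed, a higher number that more compound is needed for the effect), compound 2 `CCOC(=O)N1[C@@H]2C=C[C@@](OC)(C(=O)c3c2cc(OC)c(OC)c3OCc2ccccc2F)N1C(=O)OCC` gives 99.7 ug/mL. Compound 1 `CCCOc1c(OC)c(OC)cc2c1C(=O)[C@]1(OC)C=C[C@H]2N(C(=O)OCC)N1C(=O)OCC` reaches only the limit of > 300 ug/mL in this assay. The change between them, (ethyl in place of 2-fluorophenyl on a saturated chain carbon bound to an oxygen on an aromatic ring), gave an at least 3.0-fold higher number from compound 2 to compound 1 (0.47 log units; beyond the scatter); the size is known only as a bound, since compound 1 sits at the limit of > 300 ug/mL in this assay, at which 1 of the 3 values shown sits. Compound 3 `COc1cc2c(c(OCc3ccccc3F)c1OC)C(=O)[C@]1(OC)C=C[C@H]2N(C(=O)OCC(C)C)N1C(=O)OCC(C)C` gives 109 ug/mL; the difference between the core of compound 3 and that of compound 2 is not broken down here. Compound 4 `CCCOc1c(OC)c(OC)cc2c1C(=O)[C@]1(OC)C=C[C@H]2N(C(=O)OCC(C)C)N1C(=O)OCC(C)C` carries the same change as compound 1, (ethyl in place of 2-fluorophenyl on a saturated chain carbon bound to an oxygen on an aromatic ring), at the same place. For the measured compounds named here, the step is expected to be about as large, a 3.2-fold higher number from compound 3 to compound 4 (0.51 log units; beyond the scatter), because the one measured step of an at least 3.0-fold higher number from compound 2 to compound 1 (0.47 log units; beyond the scatter) reached at least that size. Compound 4 is therefore estimated at 350 ug/mL, with a range from 150 ug/mL to 900 ug/mL.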

Compound 4, concentration for half-maximal effect: 299 ug/mL
For compound 4 the middle estimate is 1.2-fold (0.07 log units) above the measured one; measured number inside the range.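

Swapping the 2-fluorobenzyl group for propyl gave a 2.7-fold higher number from compound 3 to compound 4 (0.44 log units; beyond the scatter) in this assay. The earlier step on the other core ran the same way, and the comparison of their sizes stays incomplete: the same change on two cores in this assay, an at least 3.0-fold higher number (0.47 log units; beyond the scatter) from compound 2 to compound 1 and a 2.7-fold higher number (0.44 log units; beyond the scatter) from compound 3 to compound 4; the limit leaves it open whether they differ. Two pairs therefore show that the direction of the change carried over between these two cores, but they do not show that its size is the same or that it would hold on any further core.

The compounds shown leave open whether the fluorine or the ring matters more, which a plain benzyl group at this place could help separate. They also leave open how the number would respond to a longer chain such as butyl, or to a chain ending in an amine.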